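This account rests on a few compounds, and the source may have more. Where it says the series, first, only, none or still open, it means among the compounds named here.

Series notes. Compound 1 `CCCCOc1ccc(C(=O)NNC(=O)c2ccc(NS(=O)(=O)c3cnc(O)nc3O)cc2)cc1`, compound 2 `Cc1ccccc1C(=O)NNC(=O)c1ccc(NS(=O)(=O)c2cnc(O)nc2O)cc1` and compound 3 `CCCCOc1ccc(C(=O)NNC(=O)c2cccc(NS(=O)(=O)c3cnc(O)nc3O)c2)cc1` have been run in a functional assay on A549 cells (Homo sapiens) for antiproliferative activity, read by MTT assay, with a stated time of 24 h; on this read-out higher numbers stand for weaker inhibition and lower numbers for stronger inhibition. In this assay compound 1 gives 9010 nM, compound 2 gives 15100 nM and compound 3 gives 7760 nM. All three numbers lie within the scatter of one another, so no order among them is claimed. Compound 1 and compound 2 share a core and differ in one place: 2-methylphenyl in place of 4-butoxyphenyl on a carbonyl carbon. That change gives a 1.7-fold higher number from compound 1 to compound 2 (0.22 log units; within the scatter). Compound 3 and compound 1 are built from the same atoms joined differently; the difference between the two cores is not broken down here. Compound 4 `Cc1ccccc1C(=O)NNC(=O)c1cccc(NS(=O)(=O)c2cnc(O)nc2O)c1` has not yet been measured. It relates to compound 3 as compound 2 relates to compound 1: 2-methylphenyl in place of 4-butoxyphenyl on a carbonyl carbon. The place is described in the same words for both pairs, so it is the same change made on the core of compound 3; among the compounds here it occurs twice. For compound 4 in this assay a step of about a 1.7-fold higher number from compound 3 to compound 4 (0.23 log units; within the scatter) is expected. For the measured compounds named here, this rests on compound 3 at 7760 nM and on the single earlier instance of the change, a 1.7-fold higher number from compound 1 to compound 2 (0.22 log units; within the scatter). Compound 4 is accordingly estimated at 13200 nM, with a range from 6500 nM to 27000 nM.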

Compound 4, half-maximal inhibitory concentration: 8010 nM
Beside the measured number, compound 4's estimate is 1.6-fold (0.22 log units) above it; low and high end bracket the measured number.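

In this assay, 2-methylphenyl in place of 4-butoxyphenyl on a carbonyl carbon gives a 1.0-fold higher number from compound 3 to compound 4 (0.01 log units; within the scatter). Read together, the two instances are compatible with the change carrying over between the two cores, and no difference between the cores is shown: the same change on two cores in this assay, a 1.7-fold higher number (0.22 log units; within the scatter) from compound 1 to compound 2 and a 1.0-fold higher number (0.01 log units; within the scatter) from compound 3 to compound 4, 1.6-fold (0.21 log units) apart, within the scatter of two such steps

Every one of these steps lies within the scatter, so the data do not show that the change has a real effect of a fixed size on either core, and two instances set no rule for other cores in the series.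

Only 4-butoxyphenyl and 2-methylphenyl appear on this carbonyl carbon, which leaves open whether any other group there moves the number beyond the scatter on either core. A phenyl carrying an amine or a carboxylic acid, or a longer chain in place of butoxy, is the kind of group on which that question remains unanswered.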